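The source may hold more compounds than are shown below. What is called first, only, known or untested is meant among the compounds shown, and "the series" means these compounds.

Compound 2 `N/C(=N\NC(=S)N1CCCCC1)c1ccccn1` gives 86% in a functional assay on HeLa cells (Homo sapiens) for cytotoxicity, read by MTT assay, with a stated time of 72 h, tested at 100 uM; on this read-out lower numbers stand for less inhibition of growth and higher numbers for more inhibition of growth at the one concentration tested. Its number stands together with those of compound 1 `N/C(=N\NC(=S)N1CCSCC1)c1ccccn1`, which gives 88.7%, and compound 3 `Cc1cccc(/C(N)=N/NC(=S)N2CCCCC2)n1`, which gives 85.4%; the steps of a number 2.7 percentage points lower from compound 1 to compound 2 (within the scatter) and a number 0.6 percentage points lower from compound 2 to compound 3 (within the scatter) are both within the scatter. Compound 4 `N/C(=N\NC(=S)N1CCCC1)c1ccccn1` differs from compound 2 by pyrrolidin-1-yl in place of piperidin-1-yl on a thiocarbonyl carbon. The step from compound 1 to compound 2 also swapped the ring on the thiocarbonyl carbon, and it was within the scatter, so for this assay no step beyond the scatter is expected from the ring in compound 4 either. Compound 4 is therefore estimated at 85%, between 72% and 95%, an expected step of a number 1 percentage points lower from compound 2 to compound 4 (within the scatter).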

Compound 4, percent growth inhibition at one concentration: 89.1%
The estimate for compound 4 lay 4.1 percentage points below the measured number; low and high end bracket the measured number.
By their numbers in this assay, from the lowest: compounds 3, 2, 1 and 4 (each within the scatter of the next).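

In this assay, the step of a number 3.1 percentage points higher from compound 2 to compound 4 (within the scatter) and the step of a number 0.4 percentage points higher from compound 1 to compound 4 (within the scatter) both lie within the scatter. A five-membered ring on the thiocarbonyl carbon therefore stands level with both six-membered rings, so a change in ring size, and not only a swap between six-membered rings, leaves the compounds unseparated here. Nothing available explains this result.

On these data alone, it remains open whether piperazin-1-yl, or an open-chain dimethylamino group, on this carbon would stay in the same range. As far as these compounds go, it also remains open whether these compounds would separate at a lower concentration.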